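Compound 3 and the Step to Compound 4

This account rests on a few compounds, and the source may have more. Where it says the series, first, only, none or still open, it means among the compounds named here.

Three related molecules have been tested in a functional assay on EC9706 cells (Homo sapiens) for antiproliferative activity, read by MTT assay, with a stated time of 72 h; on this read-out higher numbers stand for weaker inhibition and lower numbers for stronger inhibition. Compound 3 (`COc1ccc(/C=N/NC(=O)c2cccc(S(=O)(=O)N3CCOCC3)c2)c(O)c1`) gives 1090 nM, which lies within the scatter of compound 2 (`CCN(CC)c1ccc(/C=N/NC(=O)c2cccc(S(=O)(=O)N3CCOCC3)c2)c(O)c1`) at 920 nM. Compound 1 (`C/C(=N\NC(=O)c1cccc(S(=O)(=O)N2CCOCC2)c1)c1cc(F)ccc1O`) gives 2210 nM, a higher number than compound 3 and so weaker inhibition, with a gap beyond the scatter. Compound 1 differs from compound 3 in more than one place, so it offers no clean comparison.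

The next molecule, compound 4 (`O=C(N/N=C/c1cc(Br)ccc1O)c1cccc(S(=O)(=O)N2CCOCC2)c1`), changes a single group: 5-bromo-2-hydroxyphenyl in place of 2-hydroxy-4-methoxyphenyl on a carbon with a double bond to nitrogen. Among the compounds with values here, only one measured step bears on this change: methoxy in place of diethylamino on an aromatic carbon, which gave a 1.2-fold higher number from compound 2 to compound 3 (0.07 log units; within the scatter). That swap lies within the scatter and touches the same aromatic group that changes in compound 4. Within the data shown here, it is a single example, however, and no measured compound carries bromine, so the uncertainty stays wide. No shift beyond the scatter is expected, and the expected change is a 1.1-fold higher number from compound 3 to compound 4 (0.04 log units; within the scatter). For compound 4 the estimated value is 1200 nM, with an expected range from 500 nM to 2900 nM.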

Compound 4, half-maximal inhibitory concentration: 29700 nM
The estimate for compound 4 lay 25-fold (1.39 log units) below the measured number; the measured number lies above the stated range.
By their numbers in this assay, from the lowest: compounds 2 and 3 (each within the scatter of the next); then compound 1; then compound 4.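

In this assay, within the data shown here, putting 5-bromo-2-hydroxyphenyl in place of 2-hydroxy-4-methoxyphenyl gives a 27-fold higher number from compound 3 to compound 4 (1.44 log units; beyond the scatter), so a change to the aromatic group on the carbon with a double bond to nitrogen can greatly weaken inhibition, which the only earlier step on this group, a 1.2-fold higher number from compound 2 to compound 3 (0.07 log units; within the scatter), did not show. This single step removes the methoxy group and brings in bromine at once, and the two group names also carry different ring numbers, so it cannot tell which of these differences accounts for the higher number. No measurement shown here explains why the step is so large.

Going by these compounds, it remains open whether the bromine itself matters, or whether the weaker inhibition comes from losing the methoxy group that compound 3 carries. A compound with chlorine or a nitrile in place of the bromine, or one with an ethoxy group in place of the methoxy group, would help to show how much of the shared core's activity depends on this part of the molecule.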